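The source may report more compounds than this note shows. Statements on the series, on what has been measured and on what is new or still open speak of the compounds shown alone.

In an ADME assay on HEK293 cells (Homo sapiens) for cytotoxicity, read by MTT assay, with a stated time of 72 h (on this read-out higher numbers stand for weaker inhibition and lower numbers for stronger inhibition), compound 1 `O=C(CN1CCN(C(=O)c2ccc(F)cc2)CC1)N1CCN(CCCc2c[nH]c3ccccc23)CC1` gives 141000 nM and compound 2 `O=C(CN1CCN(C(=O)c2cccc(Cl)c2)CC1)N1CCN(CCCc2c[nH]c3ccccc23)CC1` gives 99100 nM. For the measured compounds named here, these are the only two measurements available, and the gap between them lies within the scatter, so the numbers do not separate compound 2 from compound 1.

Compound 3 `O=C(CN1CCN(C(=O)c2cccc(Br)c2)CC1)N1CCN(CCCc2c[nH]c3ccccc23)CC1` keeps the rest of compound 2 and differs in one place: bromo in place of chloro on an aromatic carbon. This puts bromo in place of chloro on an aromatic carbon, meta to a large group.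

Going by the values given here, no measured step covers this exchange directly. Among the compounds with values here, the closest evidence is the single step, which placed 3-chlorophenyl where 4-fluorophenyl had stood on a carbonyl carbon. That step, a 1.4-fold lower number from compound 1 to compound 2 (0.15 log units; within the scatter), stayed within the scatter. With nothing larger to draw on, no change beyond the scatter is expected in this assay, in either direction.

The expected step is small: a 1.0-fold lower number from compound 2 to compound 3 (0.02 log units; within the scatter). For compound 3 the estimated value is 95000 nM, with an expected range of 50000 nM to 180000 nM.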

Compound 3, half-maximal inhibitory concentration: 80700 nM
Compound 3: middle estimate off by 1.2-fold (0.07 log units), on the high side; low and high end bracket the measured number.
By their numbers in this assay, from the lowest: compounds 3, 2 and 1 (each within the scatter of the next).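

In this assay, the exchange of chloro for bromo on an aromatic carbon, meta to a large group, gives a 1.2-fold lower number from compound 2 to compound 3 (0.09 log units; within the scatter) and is the only step shown that changes the halogen while its place stays the same; this single exchange does not separate the two compounds. The wider exchange of 3-bromophenyl for 4-fluorophenyl on a carbonyl carbon gives a 1.7-fold lower number from compound 1 to compound 3 (0.24 log units; within the scatter) and so also stays inside the scatter, even though both the halogen and its place differ. No measured evidence is at hand that could account for these small steps or say what lies behind them.

From the compounds shown here alone, all three compounds carry a single halogen on the aromatic ring, so it remains open whether an amine, a methoxy group or a carboxylic acid at this place would shift the number in this cell assay beyond the scatter. The compounds also share the rest of the core, which leaves open what a longer chain in place of the one leading to the indole-bearing end would do.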